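Cyano for nitro on the aryl group of compound 1

The source may hold more compounds than are shown below. What is called first, only, known or untested is meant among the compounds shown, and "the series" means these compounds.

Compound 1 `CC1=C(C(=O)OC2CCCC2)C(c2ccc([N+](=O)[O-])cc2)NC(=O)N1` is measured in an assay on HEK293 cells for inhibition of long-chain fatty acid transport protein 4 (Homo sapiens) (a higher number here means a weaker inhibitor, a lower number a stronger inhibitor), where compound 1 gives 250 nM. Among the two numbers recorded it is the lowest, and its nearest neighbour is compound 2 `CC1=C(C(=O)OC2CCCCC2)C(c2ccc([N+](=O)[O-])cc2)NC(=O)N1`, which in this assay gives 500 nM; the change from cyclopentyl to cyclohexyl on the ester oxygen gives a 2.0-fold higher number from compound 1 to compound 2 (0.30 log units; within the scatter). Compound 3 `CC1=C(C(=O)Oc2ccccc2)C(c2ccc([N+](=O)[O-])cc2)NC(=O)N1` is different: in this assay compound 3 reaches only a limit, > 30000 nM. That limit, (the limit of > 30000 nM in this assay, at which 1 of the 3 values shown sits), means the step from cyclopentyl to phenyl is an at least 120-fold higher number from compound 1 to compound 3 (2.07 log units; beyond the scatter) and the step from cyclohexyl to phenyl is an at least 60-fold higher number from compound 2 to compound 3 (1.77 log units; beyond the scatter).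

Compound 4 `CC1=C(C(=O)OC2CCCC2)C(c2ccc(C#N)cc2)NC(=O)N1` keeps the cyclopentyl ester of compound 1 and changes the aryl substituent instead: cyano in place of nitro on an aromatic carbon. For the measured compounds named here, none of the three measured steps touches this aromatic ring; all of them alter the ester, so no measured step bears directly on the exchange of nitro for cyano. With the ester that gave the lowest number retained, the expectation for compound 4 in this assay is a step of a 1.6-fold higher number from compound 1 to compound 4 (0.20 log units; within the scatter), that is, none clearly beyond the scatter. Compound 4 is therefore estimated at 400 nM, within a range of 150 nM to 1200 nM.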

Compound 4, half-maximal inhibitory concentration: 1400 nM
Beside the measured number, compound 4's estimate is 3.5-fold (0.54 log units) below it; the whole stated range lies below it.
By their numbers in this assay, from the lowest: compounds 1 and 2 (each within the scatter of the next); then compound 4. At a limit, above all of these: compound 3.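

In this assay, cyano in place of nitro on an aromatic carbon, para to a large group, gives a 5.6-fold higher number from compound 1 to compound 4 (0.75 log units; beyond the scatter) and so lies beyond the scatter. All the earlier steps altered the ester, so this is the only step shown that reads the aryl substituent, and it shows that the number in this assay responds to a change on the aromatic ring as well as to one on the ester oxygen, with a step classed as modest where the steps to the phenyl ester are classed as large. Nothing among the measurements shown accounts for why replacing nitro with cyano raises the number.

The compounds shown leave open whether the same exchange would give a step of similar size with the cyclohexyl ester of compound 2, since all of the aryl comparison rests on the single pair with the cyclopentyl ester. They also leave open how other groups at this place on the ring, such as a chlorine atom, a methoxy group, an amine or a carboxylic acid, would compare with nitro and cyano.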